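The source may hold more compounds than are shown below. What is called first, only, known or untested is meant among the compounds shown, and "the series" means these compounds.

Series notes. Compound 1 `COc1ccc(C=c2s/c(=C3\C(=O)Nc4cc(F)ccc43)n(CCN(C)C)c2=O)cc1` is the reference point for the present step. In a functional assay on NCI-H460 cells (Homo sapiens) for inhibition, read by MTT assay, with a stated time of 72 h (on this read-out higher numbers stand for weaker inhibition and lower numbers for stronger inhibition), compound 1 gives 2200 nM. Two further members carry the same core with other substituents: compound 2 `COc1cc(C=c2s/c(=C3\C(=O)Nc4ccc(F)cc43)n(CCN(C)C)c2=O)cc(OC)c1OC` gives 1700 nM in this assay, and compound 3 `Cc1ccc2c(c1)/C(=c1/sc(=Cc3ccc(C=O)c(C=O)c3)c(=O)n1CCN(C)C)C(=O)N2` gives 4030 nM in this assay. The three numbers sit close together; the gap from compound 1 to either of the others falls within the usual scatter of repeated runs, so no ranking among compounds 1, 2 and 3 is claimed, and compound 1 is best described as lying in the middle of a narrow band.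

Compound 4 `CN(C)CCn1c(=O)c(=Cc2ccc(F)c(F)c2)s/c1=C1\C(=O)Nc2cc(F)ccc21` has not yet been tested. Relative to compound 1 the change is 3,4-difluorophenyl in place of 4-methoxyphenyl on a double-bonded chain carbon bound to an aromatic carbon. For the measured compounds named here, no measured pair in this set isolates this change, so there is no directly comparable step to draw on. Given that compounds 1, 2 and 3 differ at the same aryl group and still land within the scatter of one another in this assay, the expectation for compound 4 is a step of no size beyond the scatter, in either direction, a 1.1-fold higher number from compound 1 to compound 4 (0.04 log units; within the scatter). Compound 4 is accordingly estimated at 2400 nM in this assay, with a plausible range from 900 nM to 6500 nM.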

Compound 4, half-maximal inhibitory concentration: 6400 nM
For compound 4 the middle estimate is 2.7-fold (0.43 log units) below the measured one; the range from low to high includes it.
By their numbers in this assay, from the lowest: compounds 2, 1, 3 and 4 (each within the scatter of the next, the first and the last beyond it).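

In this assay, for the compounds shown here, 3,4-difluorophenyl in place of 4-methoxyphenyl on a double-bonded chain carbon bound to an aromatic carbon gives a 2.9-fold higher number from compound 1 to compound 4 (0.46 log units; beyond the scatter), the first step in this set that isolates a single place and also the first read across such a pair. The aryl group at this position therefore does move the read-out when the rest of compound 1 is held fixed, and this particular exchange moves it toward weaker inhibition, by a modest amount. The two groups have the same heavy-atom count, and the exchange removes the one hydrogen-bond acceptor of the leaving group, but nothing available links either feature to the step or otherwise explains it.

Going by these compounds, it remains open whether the step follows from the loss of the methoxy group, the arrival of the two fluorines, or both, and an unsubstituted phenyl at the same place would help to separate these. A single pair also sets no trend, so a different kind of group there, such as a carboxylic acid or an amine on the phenyl ring, could fall on either side of compound 1.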